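The source may report more compounds than this note shows. Statements on the series, on what has been measured and on what is new or still open speak of the compounds shown alone.

Among the compounds with values here, compound 2 `Brc1ccc(-c2cc(CN(c3ncccn3)c3nc4ccccc4s3)on2)cc1` gives 13600 nM in a functional assay on U-937 cells (Homo sapiens) for antiproliferative activity, read by MTT assay (a higher number here means a weaker inhibitor, a lower number a stronger inhibitor), one of only two numbers measured so far, and it sits within the scatter of compound 1 `FC(F)(F)Oc1ccc(-c2cc(CN(c3ncccn3)c3nc4ccccc4s3)on2)cc1`, which gives 13500 nM. Within the data shown here, the single measured step, a 1.0-fold higher number from compound 1 to compound 2 (0.00 log units; within the scatter), exchanged one group attached on an aromatic carbon and left the number essentially unchanged. Compound 3 `Fc1ccccc1-c1cc(CN(c2ncccn2)c2nc3ccccc3s2)on1` carries 2-fluorophenyl in place of 4-bromophenyl on an aromatic carbon. Because that one comparable step a 1.0-fold higher number from compound 1 to compound 2 (0.00 log units; within the scatter) was flat, no shift beyond the scatter is expected for compound 3, although a group of a new kind adds some uncertainty. Compound 3 is therefore estimated at 13000 nM, between 4500 nM and 38000 nM, a step of a 1.0-fold lower number from compound 2 to compound 3 (0.02 log units; within the scatter).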

Compound 3, half-maximal inhibitory concentration: 27600 nM
Estimate against measurement, compound 3: 2.1-fold (0.33 log units) below, and the stated range covers the measured number.
By their numbers in this assay, from the lowest: compounds 1 and 2 (each within the scatter of the next); then compound 3.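

This position on the shared core is not indifferent to its group, as the flat earlier step suggested: the change to 2-fluorophenyl gives a 2.0-fold higher number from compound 2 to compound 3 (0.31 log units; beyond the scatter) and, in the same direction, a 2.0-fold higher number from compound 1 to compound 3 (0.31 log units; beyond the scatter) in this assay. Both steps are modest, and nothing available explains them. As far as these compounds go, the swap changes both the halogen and its numbered place on the phenyl ring, so which of the two matters stays open. Whether an amine or a carboxylic acid on that phenyl ring would bring a lower number is also unknown.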